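A few compounds are considered here, and "the series" means these few. Any claim that something is new, unique, unknown or untested is made for them only; others in the source may bear on it.

Compound 1 (`COC(=O)c1cccc(-c2cnc(Nc3cccc(F)c3)o2)c1`) in an ADME assay on microsomes from liver (Mus musculus) for metabolic stability, read by LC-MS, using NADPH; on this read-out higher numbers stand for a longer-lived compound and lower numbers for a shorter-lived compound: < 0.0167 h
Compound 2 (`COC(=O)c1cccc(-c2cnc(Nc3ccc(F)cc3)o2)c1`) in this assay: 0.0183 h

Going by the values given here, compound 2 is the only compound of the two with a number in this assay, where compound 2 gives 0.0183 h. Compound 1, by contrast, is recorded only as a limit of this assay, < 0.0167 h, as noted in the limit of < 0.0167 h in this assay, at which 1 of the 2 values shown sits. The step of an at least 1.0-fold higher number from compound 1 to compound 2 (0.03 log units; that floor lies within the scatter) lies within the scatter.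

Compound 3 (`Cc1noc(-c2cccc(-c3cnc(Nc4ccc(F)cc4)o3)c2)n1`) differs from compound 2 in a different part of the molecule: 3-methyl-1,2,4-oxadiazol-5-yl in place of methoxycarbonyl on an aromatic carbon. Among the compounds with values here, no measured step touches this position; the single measured step altered the fluorophenyl ring and sat within the scatter, so it offers no guide to the size or direction of the change expected here. Compound 3 is therefore expected to land near compound 2, with a wide range, at an estimated 0.04 h. The step expected from compound 2 to compound 3 is a 2.2-fold higher number from compound 2 to compound 3 (0.34 log units; beyond the scatter), carrying no firm direction.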

Compound 3, half-life: 0.383 h
Compound 3: the middle estimate sits 9.6-fold (0.98 log units) below what was measured, and the stated range ends below it.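

In this assay, the aromatic carbon that carries methoxycarbonyl in compound 2 proves to be a place where the read-out moves strongly: 3-methyl-1,2,4-oxadiazol-5-yl there gives a 21-fold higher number from compound 2 to compound 3 (1.32 log units; beyond the scatter) (large and beyond the scatter). Going by these compounds alone, the earlier pair could not show this; its only step changed the fluorophenyl ring and stayed within the scatter, so this is the first clear change. A single step cannot separate the departure of methoxycarbonyl from the arrival of the new ring, and nothing available here accounts for the gain.

As far as these compounds go, whether an amide, a nitrile or a carboxylic acid on this carbon would give a similar half-life remains open. Also open, from the compounds shown here alone, is whether the same exchange would carry over to the 3-fluorophenyl series.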